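Halogen steps on the distal ring: toward compound 3

A few compounds are considered here, and "the series" means these few. Any claim that something is new, unique, unknown or untested is made for them only; others in the source may bear on it.

Measured so far:
compound 1, `CC(=O)Nc1ccc(S(=O)(=O)NNc2ccc(Cl)cc2)cc1`, 142 nM
compound 2, `CC(=O)Nc1ccc(S(=O)(=O)NNc2ccc(Br)cc2)cc1`, 85 nM

Compound 1 stands highest of the two numbers in an assay on HeLa cells for inhibition of Indoleamine 2,3-dioxygenase 1 (Homo sapiens), read by spectrophotometry, with a stated time of 24 h; a higher number here means that more compound is needed for the effect, a lower number that less compound is needed; its nearest is compound 2, with a 1.7-fold lower number from compound 1 to compound 2 (0.22 log units; within the scatter). Compound 3, `CC(=O)Nc1ccc(S(=O)(=O)NNc2ccc(Cl)c(Cl)c2)cc1`, differs from compound 1 by chloro in place of hydrogen on an aromatic carbon. For the measured compounds named here, the only measured step, from compound 1 to compound 2, swaps one halogen for another and stays within the scatter; adding a second chloro group has no precedent here. No movement beyond the scatter is therefore expected. Compound 3 is expected near compound 1 in this assay. The estimate for compound 3 is 120 nM, from 40 nM to 400 nM, meaning an expected 1.2-fold lower number from compound 1 to compound 3 (0.07 log units; within the scatter).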

Compound 3, half-maximal effective concentration: 350 nM
For compound 3 the middle estimate is 2.9-fold (0.46 log units) below the measured one; low and high end bracket the measured number.
By their numbers in this assay, from the lowest: compounds 2 and 1 (each within the scatter of the next); then compound 3.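

In this assay, for the compounds shown here, the added chloro group, ortho to a chloro group, gives a 2.5-fold higher number from compound 1 to compound 3 (0.39 log units; beyond the scatter) and is the first step to pass the scatter, though only modestly. The earlier swap of chloro for bromo left the number within the scatter, so substitution at this further aromatic carbon shows a movement that the halogen exchange did not. No measurement at hand accounts for the shift.

From the compounds shown here alone, whether a fluoro or methoxy group on this carbon moves the number as chloro does remains open. Also open, going by these compounds, is whether the step depends on the chloro group already present.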